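The source may report more compounds than this note shows. Statements on the series, on what has been measured and on what is new or still open speak of the compounds shown alone.

Measured compounds:
Compound 1, `CSc1nn(-c2ccc(S(N)(=O)=O)cc2)c2nc(Nc3ccccc3)n(-c3ccccc3)c(=O)c12`: 68.9%
Compound 2, `Cc1ccc(Nc2nn(-c3ccccc3)c3nc(Nc4ccccc4)n(-c4ccccc4)c(=O)c23)cc1`: 55.7%

In a functional assay on the whole organism (strain Wistar albino) for inhibition, with Rattus norvegicus as the target, read by paw edema, with a stated time of 1 h, at a dose of 25 mg/kg by the oral route (on this read-out higher numbers stand for more inhibition at the one dose given (going by the name of the read-out) and lower numbers for less inhibition), compound 1 gives 68.9%, and compound 2 gives 55.7%. Compound 2 stands lowest of the two numbers; its nearest neighbour is compound 1, whose number lies higher by a gap beyond the usual scatter. These two compounds differ in more than one place, so their gap is simply what the two values show, with no single change to attach it to.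

Compound 3, `Cc1ccc(Nc2nn(-c3ccc(S(N)(=O)=O)cc3)c3nc(Nc4ccccc4)n(-c4ccccc4)c(=O)c23)cc1`, has not yet been measured in this assay. It differs from compound 2 in one place only: sulfamoyl in place of hydrogen on an aromatic carbon. Compound 1 also carries a sulfamoyl group, and it is the higher of the two measured compounds. The expected step is a number 8.3 percentage points higher from compound 2 to compound 3 (within the scatter), an upward move of moderate size, somewhat beyond the scatter, because compound 1 gives 68.9% with the same group present. For the measured compounds named here, with only one supporting compound the expectation is loose. Compound 3 is estimated at 64%, with a range from 52% to 76%.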

Compound 3, a percentage reported as inhibition, in the whole organism at one dose (the size of the read-out at that dose, not a potency): 77%
Beside the measured number, compound 3's estimate is 13 percentage points below it; measured number outside the range, above it.
By their numbers in this assay, from the lowest: compound 2; then compounds 1 and 3 (each within the scatter of the next).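

In this assay, for the compounds shown here, going from phenyl to 4-sulfamoylphenyl gives a number 21.3 percentage points higher from compound 2 to compound 3 (beyond the scatter) and so provides the first single change that can be read on its own: sulfamoyl in place of hydrogen at this ring position, para to a large group, moves the read-out beyond the usual scatter. At the other site, with sulfamoyl present in both compounds, (4-methylphenyl)amino in place of methylsulfanyl gives a number 8.1 percentage points higher from compound 1 to compound 3 (within the scatter) and so does not separate these two groups on this read-out. Nothing shown here speaks to what lies behind either step.

The compounds shown leave open whether the sulfamoyl step would be the same with methylsulfanyl at the other site, since it rests on the single pair of compound 2 and compound 3. They also leave open whether a smaller amine or a carboxylic acid at the same ring position would give a similar number, or whether this result belongs to sulfamoyl in particular.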